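A 1,3-benzoxazol-2-yl group enters at compound 3

The compounds below may be only part of what the source reports. "The series", "measured", "known", "first", "only" and "open" are said of these compounds alone.

Compound 1 `COc1ccc2nc(COc3ccc4c(c3)c(SC(C)(C)C)c(CC(C)(C)C(=O)O)n4Cc3ccc(Cl)cc3)sc2c1` gives 8 nM
Compound 2 `Cc1nc2ccc(COc3ccc4c(c3)c(SC(C)(C)C)c(CC(C)(C)C(=O)O)n4Cc3ccc(Cl)cc3)cc2s1` gives 6 nM

In a functional assay for inhibition, with Homo sapiens as the target (on this read-out lower numbers stand for stronger inhibition and higher numbers for weaker inhibition), compound 2 gives 6 nM and so sits within the scatter of compound 1. The next structure, compound 3 `CC(C)(C)Sc1c(CC(C)(C)C(=O)O)n(Cc2ccc(Cl)cc2)c2ccc(OCc3nc4ccccc4o3)cc12`, has 1,3-benzoxazol-2-yl in place of 2-methyl-1,3-benzothiazol-6-yl on a saturated chain carbon bound to an oxygen on an aromatic ring. In detail, 1,3-benzoxazol-2-yl in place of 2-methyl-1,3-benzothiazol-6-yl on a saturated chain carbon bound to an oxygen on an aromatic ring while the rest of the structure stays the same. For the measured compounds named here, only one measured step bears on this place: a 1.3-fold lower number from compound 1 to compound 2 (0.12 log units; within the scatter) in an exchange of two other groups. Going by the values given here, that single step is thin evidence, and no measured compound carries the entering group. Nothing here points to a move beyond the scatter in this assay so none is expected. The estimated change is a 1.7-fold higher number from compound 2 to compound 3 (0.22 log units; within the scatter) and thus no real shift. For compound 3 the estimate is 10 nM with an expected range of 3 nM to 30 nM in this read-out.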

Compound 3, half-maximal inhibitory concentration: < 7 nM
Compound 3 gave a limit, no number; the forecaster's own chance of this, stated with the estimate: 2%; middle value at least 1.4-fold (0.15 log units) from the limit.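

In this assay, compound 3 is reported only as a limit of the assay, not as a number: the limit of < 7 nM in this assay, at which 1 of the 3 values shown sits.

For the compounds shown here, the one readable step is an at least 1.1-fold lower number from compound 1 to compound 3 (0.05 log units; that floor lies within the scatter), while the step from compound 2 to compound 3 cannot be read. Going by these compounds alone, this shows for the first time that the place on a saturated chain carbon bound to an oxygen on an aromatic ring accepts 1,3-benzoxazol-2-yl, with oxygen entering and sulfur leaving, without any weakening relative to compound 1.

On these data alone, how far the true value of compound 3 lies past its limit remains open, and so does whether its inhibition really differs from that of compound 1 or compound 2. As far as these compounds go, it is also open whether this place would hold such inhibition with a plain phenyl or an amine in place of the 1,3-benzoxazol-2-yl.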